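Swapping the Sulfonyl Aryl Group of a Potent EP3 Antagonist

This account rests on a few compounds, and the source may have more. Where it says the series, first, only, none or still open, it means among the compounds named here.

The series rests on a shared core, a fused bicyclic system carrying a 2,4-dichlorobenzyl substituent and an acylsulfonamide side chain. Compound 1 `Cc1ncc(S(=O)(=O)NC(=O)NC/C=C2\CCCc3cnn(Cc4ccc(Cl)cc4Cl)c32)s1` and compound 2 `Cc1nc(C)c(S(=O)(=O)NC(=O)NC/C=C2\CCCc3cnn(Cc4ccc(Cl)cc4Cl)c32)s1` differ only in that compound 2 carries a methyl in place of hydrogen on an aromatic carbon of the thiazole; compound 3 `CS(=O)(=O)c1ccc(-n2ncc3c2/C(=C/CNC(=O)NS(=O)(=O)c2cc(Cl)c(Cl)s2)CCC3)cc1` has a different aryl group on the sulfonyl and a different substituent on the core. In a functional assay on CHO-K1 cells for antagonist activity at prostaglandin E2 receptor EP3 subtype (Homo sapiens), read by TR-FRET and cAMP accumulation, with a stated time of 30 min (a lower number here means a stronger inhibitor, a higher number a weaker inhibitor), compound 1 gives 9 nM, compound 2 gives 4 nM and compound 3 gives 30 nM. Compound 2 stands at the lowest of the three numbers, and the step of a 2.3-fold lower number from compound 1 to compound 2 (0.35 log units; beyond the scatter) shows that the added methyl strengthened inhibition modestly.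

Compound 4 `COc1ccccc1S(=O)(=O)NC(=O)NC/C=C1\CCCc2cnn(Cc3ccc(Cl)cc3Cl)c21` is the next step from compound 2: 2-methoxyphenyl in place of 2,4-dimethyl-1,3-thiazol-5-yl on a sulfonyl sulfur. For the measured compounds named here, no measured step changes the sulfonyl aryl group on this core, so the only related observation is that the thiazole methyl mattered modestly in a 2.3-fold lower number from compound 1 to compound 2 (0.35 log units; beyond the scatter), which suggests the sulfonyl aryl region is sensitive to change. Losing the heteroaryl ring entirely is therefore expected to cost some potency in this assay, as the step of a 3.8-fold higher number from compound 2 to compound 4 (0.57 log units; beyond the scatter), giving an estimated value for compound 4 of 15 nM with a range from 5 nM to 50 nM.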

Compound 4, half-maximal inhibitory concentration: 114 nM
Compound 4: the middle estimate sits 7.6-fold (0.88 log units) below what was measured, outside the stated range (above it).
By their numbers in this assay, from the lowest: compound 2; then compound 1; then compound 3; then compound 4.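

In this assay, the change from 2,4-dimethyl-1,3-thiazol-5-yl to 2-methoxyphenyl on the sulfonyl sulfur produces a large loss, a 29-fold higher number from compound 2 to compound 4 (1.45 log units; beyond the scatter), well beyond the modest gain seen with the thiazole methyl, a 2.3-fold lower number from compound 1 to compound 2 (0.35 log units; beyond the scatter). The loss also appears when the comparison starts from the thiazole with one fewer methyl, at a 13-fold higher number from compound 1 to compound 4 (1.10 log units; beyond the scatter), so among these compounds it does not depend on which of the two thiazoles is replaced, and the identity of the whole aryl group at this position matters far more than that single methyl. No measurement available here bears on why this replacement weakens inhibition so strongly.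

The step changes the ring and its substituents together, so the compounds shown cannot separate the loss of the thiazole ring from the arrival of the methoxy group. On these data alone, it remains open whether an unsubstituted phenyl, a pyridine ring or a thiophene ring on the sulfonyl sulfur of this core would stay close to the thiazoles or fall back toward the methoxyphenyl compound 4.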